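Benzyl halogen exchange in a rhodanine acetic acid series

The source may report more compounds than this note shows. Statements on the series, on what has been measured and on what is new or still open speak of the compounds shown alone.

Measured compounds
compound 1: `O=C(O)CN1C(=O)/C(=C/c2nc3ccccc3n2Cc2ccc(Br)cc2F)SC1=S` — > 50000 nM
compound 2: `O=C(O)CN1C(=O)/C(=C/c2nc3ccccc3n2Cc2ccc(F)cc2F)SC1=S` — 26100 nM

In a functional assay on HeLa cells (Homo sapiens) for cytotoxicity, read by MTT assay, with a stated time of 48 h (on this read-out higher numbers stand for weaker inhibition and lower numbers for stronger inhibition), compound 1 reaches only the limit of the assay, (the limit of > 50000 nM in this assay, at which 1 of the 2 values shown sits), so no number is known for it. Compound 2 gives 26100 nM in this assay. For the measured compounds named here, the one measured step, an at least 1.9-fold lower number from compound 1 to compound 2 (0.28 log units; that floor lies within the scatter), is the only comparison available, and its floor lies within the usual scatter, so the two compounds cannot be ordered.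

Compound 3 is `O=C(O)CN1C(=O)/C(=C/c2nc3ccccc3n2Cc2ccc(F)c(F)c2)SC1=S`. It differs from compound 1 by 3,4-difluorophenyl in place of 4-bromo-2-fluorophenyl on a saturated chain carbon bound to an aromatic nitrogen, with the benzyl group then read as 3,4-difluorobenzyl in place of 4-bromo-2-fluorobenzyl. As in compound 2, bromine is gone and two fluorines remain, though arranged differently; the step to compound 2 is the only one that bears on this change, and it was small at most. Compound 3 is therefore expected to sit near compound 2, with an at least 1.4-fold lower number from compound 1 to compound 3 (0.15 log units; that floor lies within the scatter) meaning a weak, limit-bound change. The estimate for compound 3 in this assay is 35000 nM, between 15000 nM and 100000 nM, with a real chance that only a limit is reported.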

Compound 3, half-maximal inhibitory concentration: 16000 nM
For compound 3 the middle estimate is 2.2-fold (0.34 log units) above the measured one; low and high end bracket the measured number.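

For the compounds shown here, the change from 4-bromo-2-fluorobenzyl to 3,4-difluorobenzyl, on a saturated chain carbon bound to an aromatic nitrogen, gives an at least 3.1-fold lower number from compound 1 to compound 3 (0.49 log units; beyond the scatter), the first step to clear the scatter in this assay. Exchange of 2,4-difluorophenyl for 3,4-difluorophenyl at the same place gives a 1.6-fold lower number from compound 2 to compound 3 (0.21 log units; within the scatter), so the two difluorinated groups cannot be told apart on this read-out, and only the pattern that keeps bromine has a step beyond the scatter against a bromine-free partner. Compound 1 stays a limit and not a number, so the size of the larger step is known only as a minimum: the limit of > 50000 nM in this assay, at which 1 of the 3 values shown sits.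

From the compounds shown here alone, it remains open whether bromine as such sets the weak reading, or whether any larger group at this place would do the same, as a chlorine-bearing benzyl, a methoxy-bearing benzyl or an unsubstituted benzyl could show. Going by these compounds, it is also open how far the number can fall at this place, as every value shown here remains in the same high range, with no amine or longer chain on the benzyl group to test it.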